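The source may report more compounds than this note shows. Statements on the series, on what has been measured and on what is new or still open speak of the compounds shown alone.

Measured so far in the series:

Compound 1 `Clc1cccc(-c2cnc[nH]2)c1`, in an assay on cells for inhibition of Indoleamine 2,3-dioxygenase 1 (Homo sapiens), read by HPLC, with a stated time of 20 min (on this read-out lower numbers stand for stronger inhibition and higher numbers for weaker inhibition), gives 2600 nM.
Compound 2 `Cn1cncc1-c1ccccc1N` gives 1700000 nM.
Compound 3 `Clc1cccc(-n2ccnc2)c1` gives 41000 nM.

Compound 3 stands second highest of the three numbers. Its nearest neighbour is compound 1, whose number is lower by a gap beyond the scatter; its furthest is compound 2, whose number is higher by a gap also beyond the scatter. Compound 3 therefore sits well apart from both ends.

Compound 4 `Nc1ccc(Cl)cc1-n1ccnc1` differs from compound 3 in one place: amino in place of hydrogen on an aromatic carbon. Among the compounds with values here, no measured pair shows this change on its own. Compound 2 also carries an amino group on its six-membered ring, but it differs from compound 3 in more than one place, so its high number cannot be read as the effect of the amino group alone.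

For compound 4 in this assay the expected step is modest and its direction uncertain, leaning to a somewhat higher number. The expected step of a 1.5-fold higher number from compound 3 to compound 4 (0.17 log units; within the scatter) is estimated to lie near the edge of the scatter. Compound 4 is estimated at 60000 nM, within 12000 nM to 300000 nM.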

Compound 4, half-maximal inhibitory concentration: 88000 nM
Compound 4: middle estimate off by 1.5-fold (0.17 log units), on the low side; the measured number falls inside the stated range.
By their numbers in this assay, from the lowest: compound 1; then compound 3; then compound 4; then compound 2.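

In this assay, within the data shown here, amino in place of hydrogen on an aromatic carbon, ortho to a group of 5 heavy atoms and para to a chloro group, gives a 2.1-fold higher number from compound 3 to compound 4 (0.33 log units; beyond the scatter) as the first step that isolates a single change. This position therefore takes the amino group with a modest loss of inhibition rather than a collapse. Nothing at hand accounts for the direction of this step.

As far as these compounds go, whether the loss belongs to the amino group itself or to any substituent at this position stays open, and a fluoro or methoxy group in the same place would separate the two. Also open, from the compounds shown here alone, is whether the same amino change on the core of compound 1 would give a step of similar size and direction.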